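The source may hold more compounds than are shown below. What is called first, only, known or untested is meant among the compounds shown, and "the series" means these compounds.

Measured in a functional assay on HEK293 cells for agonist activity at D(4) dopamine receptor (Homo sapiens), read by FLIPR; a higher number here means a larger maximal response, a lower number a smaller maximal response:

compound 1, `O=C(CN1CCC(c2cccc[n+]2[O-])CC1)Nc1cccc(F)c1`, gives 70%
compound 2, `O=C(CN1CCC(c2cccc[n+]2[O-])CC1)Nc1ccc(F)cc1`, gives 71%
compound 3, `O=C(CN1CCC(c2cccc[n+]2[O-])CC1)Nc1cccc(-c2ccccc2)c1`, gives 75%

Compound 3 stands no further from either of the other two than the usual scatter allows: a number 5 percentage points higher from compound 1 to compound 3 (within the scatter), and the value of compound 2 lies about as close to that of compound 3. Nothing among the three numbers can be told apart.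

Compound 4, `O=C(CN1CCC(c2cccc[n+]2[O-])CC1)Nc1cccc(Cl)c1`, differs from compound 3 in one place: chloro in place of phenyl on an aromatic carbon. For the measured compounds named here, two measured steps bear on this. The step of a number 5 percentage points higher from compound 1 to compound 3 (within the scatter) is the near reverse of the change at hand, with fluoro rather than chloro at the same position, and was within the scatter. The step of a number 1 percentage points higher from compound 1 to compound 2 (within the scatter), which moves the fluoro group, was within the scatter as well. Neither gives any reason to expect the halogen-bearing compound 4 to move beyond the scatter from compound 3; the expected step is a number 4 percentage points lower from compound 3 to compound 4 (within the scatter). Compound 4 is therefore estimated at 71%, with a range from 61% to 81%.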

Compound 4, largest response reached (reported as efficacy), in percent of the reference or control that the assay uses: 76%
The estimate for compound 4 lay 5 percentage points below the measured number; the range from low to high includes it.
By their numbers in this assay, from the lowest: compounds 1, 2, 3 and 4 (each within the scatter of the next).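

In this assay, the position meta to a large group tolerates a swap between groups of very different size without a readable change: a number 1 percentage points higher from compound 3 to compound 4 (within the scatter). Exchanging one halogen for the other at this position also stays inside the noise, at a number 6 percentage points higher from compound 1 to compound 4 (within the scatter), and the change that alters both the halogen and its place on the ring gives a number 5 percentage points higher from compound 2 to compound 4 (within the scatter). The maximal response therefore does not separate chloro, fluoro and phenyl here, and nothing available accounts for this insensitivity.

As far as these compounds go, whether an amine or a carboxylic acid at this position would move the maximal response beyond the scatter remains open. From the compounds shown here alone, the effect of changing the shared core, which is the same in all four compounds, also remains open.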